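Bromo for Chloro Where Every Value Is an Assay Limit

The source may hold more compounds than are shown below. What is called first, only, known or untested is meant among the compounds shown, and "the series" means these compounds.

Compound 1 `CCOC(=O)c1c(-c2cccc(Cl)c2)[nH]c2cc(OC)ccc2c1=O`: in an ADME assay on HepG2 cells (Homo sapiens) for cytotoxicity, read by luminescence, with a stated time of 72 h (a higher number here means that more compound is needed for the effect, a lower number that less compound is needed), compound 1 gives > 21500 nM, a limit of the assay.
Compound 2 `CCOC(=O)c1c(-c2cccc(Br)c2)[nH]c2cc(OC)ccc2c1=O`: in this assay compound 2 gives > 21500 nM, a limit of the assay.
Compound 3 `CCOC(=O)c1c(-c2cccc(Cl)c2)[nH]c2cc(OC)c(Cl)cc2c1=O`: in this assay compound 3 gives > 21500 nM, a limit of the assay.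

Compound 2 differs from compound 1 by bromo in place of chloro on an aromatic carbon. The step that the two limits leave unreadable from compound 1 to compound 2 cannot be sized due to the limit of > 21500 nM in this assay, at which 3 of the 3 values shown sit. Compound 3 differs from compound 1 by chloro in place of hydrogen on an aromatic carbon, and the step that the two limits leave unreadable from compound 1 to compound 3 is likewise unreadable. Compound 4 `CCOC(=O)c1c(-c2cccc(Br)c2)[nH]c2cc(OC)c(Cl)cc2c1=O` differs from compound 3 by bromo in place of chloro on an aromatic carbon, the same change as from compound 1 to compound 2. Since every value stands at the limit, the expected step is a step that the limit leaves unreadable from compound 3 to compound 4, resting on (the limit of > 21500 nM in this assay, at which 3 of the 3 values shown sit). Compound 4 is estimated at 40000 nM, most likely again reported only as a limit.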

Compound 4, half-maximal effective concentration: > 21500 nM
Compound 4: a limit, no number (the forecaster's own chance of this, stated with the estimate: 90%); the middle value is on the limit's open side.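

Compound 4 also gives only a limit, so neither its step from compound 3 nor its step from compound 2 can be read: the limit of > 21500 nM in this assay, at which 4 of the 4 values shown sit. The compounds shown leave open whether bromo for chloro, or chloro for hydrogen, changes the half-maximal effective concentration in this assay at all.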